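A few compounds are considered here, and "the series" means these few. Any claim that something is new, unique, unknown or untested is made for them only; others in the source may bear on it.

Among the measured compounds shown here, compound 1 `COc1cc(-n2ncnc2-c2ccc(C)cc2)cc(OC)c1OC` carries a 4-methylphenyl group and in a functional assay on A549 cells (Homo sapiens) for antiproliferative activity, read by MTT assay, with a stated time of 72 h (a higher number here means a weaker inhibitor, a lower number a stronger inhibitor), gives 1100 nM, the only number in the set. Compound 2 `COc1cc(-c2ncnn2-c2ccc(N)cc2)cc(OC)c1OC` reaches the limit > 10000 nM in this assay. Compound 3 `COc1ccc(-n2ncnc2-c2cc(OC)c(OC)c(OC)c2)cc1` likewise stops at the limit > 10000 nM. For the measured compounds named here, the one measured step, a step that the two limits leave unreadable from compound 2 to compound 3, cannot be sized, since (the limit of > 10000 nM in this assay, at which 2 of the 3 values shown sit). Compound 4 `COc1cc(-n2ncnc2-c2ccc(F)cc2)cc(OC)c1OC` differs from compound 1 by fluoro in place of methyl on an aromatic carbon. Going by the values given here, no measured step touches this change, and the single measured step has no readable size, so nothing here points to movement beyond the scatter. The step of a 1.4-fold higher number from compound 1 to compound 4 (0.13 log units; within the scatter) is therefore expected to be small. Compound 4 is estimated at 1500 nM in this assay, with a range from 500 nM to 5000 nM.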

Compound 4, half-maximal inhibitory concentration: > 10000 nM
Compound 4 was reported as a limit; the forecaster's own chance of this, stated with the estimate: 15%; at least 6.6-fold (0.82 log units) between middle value and limit.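

Exchanging 4-methylphenyl for 4-fluorophenyl on the core of compound 1 gives, in this assay, an at least 9.0-fold higher number from compound 1 to compound 4 (0.95 log units; beyond the scatter). Among the compounds shown here, this is the first readable step, and it shows that a single-atom change on the aromatic carbon para to a large group can move the result beyond the scatter. Its full size cannot be read, because compound 4 gives only a limit: the limit of > 10000 nM in this assay, at which 3 of the 4 values shown sit.

Going by these compounds, what an ethyl group or a chloro group at this place would give stays open. On these data alone, whether any replacement for methyl here can match compound 1 also stays open.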